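The source may hold more compounds than are shown below. What is called first, only, known or untested is meant among the compounds shown, and "the series" means these compounds.

Compound 1 `CCCCCCCCCCCCCCCCCCOC1(c2ccc(Br)cc2)SC=C(C)n2c1noc2=O` belongs to a small set of analogues sharing one core and tested for antiproliferative activity. In a functional assay on A2780/DX3 cells (Homo sapiens) for antiproliferative activity, read by MTT assay, with a stated time of 3 days (a higher number here means a weaker inhibitor, a lower number a stronger inhibitor), compound 1 gives > 100000 nM, which is a limit of the assay rather than a number. The related compound 2 `COC1(c2ccc(Br)cc2)SC=C(C)n2c1noc2=O` gives > 100000 nM in this assay, again a limit. Compound 3 `CC1=CSC(O)(c2cccc(Cl)c2)c2noc(=O)n21`, which carries a hydroxyl and a meta-chloro aryl in place of the alkoxy and bromo aryl, gives > 100000 nM in this assay, once more a limit. Compound 1 thus stands nowhere apart from its neighbours: all three values sit at the limit of > 100000 nM in this assay, at which 3 of the 3 values shown sit, so no step between measured compounds can be read, and neither the length of the alkoxy chain nor the choice of aryl has yet shown any effect that the assay could resolve.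

Compound 4 `CCCCCCCCCCCCCCCCCCOC1(c2ccc(Cl)cc2)SC=C(C)n2c1noc2=O` differs from compound 1 by chloro in place of bromo on an aromatic carbon. With every measured analogue at the limit, the expected step of a number no higher from compound 1 to compound 4 (the limit leaves the size open) is none beyond the scatter, and a limit is again the most likely report. Compound 4 is therefore estimated at 100000 nM, with a range from 30000 nM to 300000 nM.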

Compound 4, half-maximal inhibitory concentration: > 100000 nM
Compound 4 gave a limit, no number; the forecaster's own chance of this, stated with the estimate: 85%; the middle value lies on the limit itself.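

In this assay compound 4 gives > 100000 nM, a limit and not a number. Going by these compounds alone, compound 1 also stands at a limit, and no step between compound 1 and compound 4 can be read. The compounds shown leave open whether chloro or bromo matters, and whether any analogue on the shared core reaches a measurable antiproliferative value.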